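The compounds below may be only part of what the source reports. "The series", "measured", "known", "first", "only" and "open" are said of these compounds alone.

Three compounds share one core and have each been measured in a functional assay on A549 cells (Homo sapiens) for antiproliferative activity, read by MTT assay, with a stated time of 48 h; on this read-out lower numbers stand for stronger inhibition and higher numbers for weaker inhibition. Compound 1 `Clc1cccc(Nc2ncnc3ccc(NCc4cccnc4)cc23)c1` gives 2670 nM. Compound 2 `CCCCNc1ccc2ncnc(Nc3cccc(Cl)c3)c2c1` gives 4010 nM, and the step of a 1.5-fold higher number from compound 1 to compound 2 (0.18 log units; within the scatter) changes only the side chain on the amine. Compound 3 `O=C(/C=C/c1cccnc1)Nc1ccc2ncnc(Nc3cccc(Cl)c3)c2c1` gives 4320 nM, the largest of the three numbers, yet its gaps to compound 2 and to compound 1 both lie within the scatter, so the three are not truly separated. Compound 4 `O=C(/C=C/c1cccc(Br)n1)Nc1ccc2ncnc(Nc3cccc(Cl)c3)c2c1` has not yet been measured; it differs from compound 3 by 6-bromopyridin-2-yl in place of pyridin-3-yl on a double-bonded chain carbon bound to a double-bonded chain carbon. Among the measured compounds shown here, no measured step touches this part of the molecule, and the one step available stayed within the scatter, so the step of a 1.0-fold lower number from compound 3 to compound 4 (0.00 log units; within the scatter) is expected to stay within the scatter too. Compound 4 is estimated at 4300 nM, with a range from 1500 nM to 12000 nM.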

Compound 4, half-maximal inhibitory concentration: 4160 nM
For compound 4 the middle estimate is 1.0-fold (0.01 log units) above the measured one; the measured number falls inside the stated range.
By their numbers in this assay, from the lowest: compounds 1, 2, 4 and 3 (each within the scatter of the next).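

In this assay, placing 6-bromopyridin-2-yl instead of pyridin-3-yl on the double-bonded chain carbon gives a 1.0-fold lower number from compound 3 to compound 4 (0.02 log units; within the scatter). Among the compounds shown here, this is the first look at this part of the molecule, and here a ring carrying a bromine leaves the number within the scatter. No measured evidence accounts for this result. The change swaps the ring's attachment point and adds bromine together, so the compounds shown do not separate the two. From the compounds shown here alone, how an amine or a carboxylic acid on this chain carbon would read also stays open.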